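Cyclopropyl for isopropyl on the core of compound 2

A few compounds are considered here, and "the series" means these few. Any claim that something is new, unique, unknown or untested is made for them only; others in the source may bear on it.

Compound 1 `CC(C)c1ccc2[nH]c(=O)c(CN(Cc3ccc(F)cc3)Cc3ccc(C(C)(C)C)cc3)cc2c1` gives 7900 nM in a toxicity assay on MDCK cells (Canis lupus familiaris) for cytotoxicity, read by crystal violet staining, with a stated time of 48 h; a lower number here means that less compound is tolerated, a higher number that more compound is tolerated. Compound 2 `CC(C)c1ccc2[nH]c(=O)c(CN(Cc3ccc(C(C)(C)C)cc3)C(C)c3ccc(N(C)C)c(Cl)c3)cc2c1` gives only a limit there, > 10000 nM. Compound 3 `COc1ccc([C@H](C)N(Cc2ccc(C(C)(C)C)cc2)Cc2cc3cc(C(C)C)ccc3[nH]c2=O)cc1` likewise gives only a limit, > 10000 nM. Compound 2 therefore stands at the limit of > 10000 nM in this assay, at which 2 of the 3 values shown sit. The steps of an at least 1.2-fold higher number from compound 1 to compound 2 (0.10 log units; that floor lies within the scatter) and an at least 1.2-fold higher number from compound 1 to compound 3 (0.10 log units; that floor lies within the scatter) are read as floors only, and a step that the two limits leave unreadable from compound 2 to compound 3. Compound 4 `CC(c1ccc(N(C)C)c(Cl)c1)N(Cc1ccc(C(C)(C)C)cc1)Cc1cc2cc(C3CC3)ccc2[nH]c1=O` differs from compound 2 by cyclopropyl in place of isopropyl on an aromatic carbon. Among the measured compounds shown here, none of the measured steps touches this position; all three vary the group on the amine nitrogen. No step beyond the scatter is therefore expected in this assay, that is a step that the limit leaves unreadable from compound 2 to compound 4. Compound 4 is estimated at 12000 nM, within 5000 nM to 30000 nM, most likely again reported as a limit.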

Compound 4, half-maximal cytotoxic concentration: > 10000 nM
Compound 4: no number, only a limit; the forecaster's own chance of this, stated with the estimate: 70%; the middle value lies beyond the limit too.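

Compound 2 and compound 4 both give only limits in this assay, and no step can be read between them. The compounds shown leave open whether cyclopropyl in place of isopropyl shifts the half-maximal cytotoxic concentration at all.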